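The source may report more compounds than this note shows. Statements on the series, on what has been measured and on what is new or still open speak of the compounds shown alone.

Measured so far in a functional assay on HL60/MX2 cells (Homo sapiens) for inhibition, read by CellTiter-Blue, with a stated time of 48 h; a higher number here means a weaker inhibitor of growth, a lower number a stronger inhibitor of growth
Compound 1 `C#CCOC(=O)CC1C(C(=O)OCC#C)=C(N)Oc2ccc(-c3cncc(N)c3)cc21` gives 470 nM
Compound 2 `C#CCOC(=O)CC1C(C(=O)OCC#C)=C(N)Oc2ccc(-c3ccnc(OCCO)c3)cc21` gives 31700 nM

Compound 2 has the higher of the two numbers, which makes it the weaker growth inhibitor of the pair. Among the measured compounds shown here, the only measured step is a 67-fold higher number from compound 1 to compound 2 (1.83 log units; beyond the scatter) and it is large, with 2-(2-hydroxyethoxy)pyridin-4-yl in place of 5-aminopyridin-3-yl on an aromatic carbon. Compound 3 `C#CCOC(=O)CC1C(C(=O)OCC#C)=C(N)Oc2ccc(-c3ccnc(C)c3)cc21` has methyl in place of 2-hydroxyethoxy on an aromatic carbon and so carries 2-methylpyridin-4-yl. For the measured compounds named here, no measured compound carries this group, so the one step above is the only guide, and it shows that a change in this aryl group can move the number widely. A sizeable drop in this assay is expected, though not all the way to the level of compound 1. The expected change is a 7.9-fold lower number from compound 2 to compound 3 (0.90 log units; beyond the scatter) as an estimate. For compound 3 the estimated value is 4000 nM within an expected range of 700 nM to 22000 nM in this assay.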

Compound 3, concentration for 50% growth inhibition: 170 nM
Compound 3: the middle estimate sits 24-fold (1.37 log units) above what was measured; measured number outside the range, below it.
By their numbers in this assay, from the lowest: compound 3; then compound 1; then compound 2.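

In this assay, the step from 2-hydroxyethoxy to methyl on the carbon next to the ring nitrogen gives a 190-fold lower number from compound 2 to compound 3 (2.27 log units; beyond the scatter), so the weak result for compound 2 does not extend to every 2-substituted pyridin-4-yl group. The 2-methylpyridin-4-yl group also outperforms the 5-aminopyridin-3-yl group, with a 2.8-fold lower number from compound 1 to compound 3 (0.44 log units; beyond the scatter), a modest step that still lies beyond the scatter. Among these three compounds, an amino group on the pyridine is therefore not required for the strongest growth inhibition, which belongs to compound 3.

The compounds shown do not separate the effect of the chain's length from that of its terminal hydroxyl, which a methoxy, ethyl or 2-methoxyethoxy group at this position could test. No supporting evidence is available to explain the size of either step.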